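A Methoxy Step Tested for Macrophage Cytotoxicity

The compounds below may be only part of what the source reports. "The series", "measured", "known", "first", "only" and "open" are said of these compounds alone.

Measured compounds:
compound 1 `O=C(Nc1cc(C(F)(F)F)cc(C(F)(F)F)c1)c1cccc(Cl)c1` gives > 60000 nM, a limit of the assay.
compound 2 `COc1ccc(Cl)cc1C(=O)Nc1cc(C(F)(F)F)cc(C(F)(F)F)c1` gives > 60000 nM, also a limit.
compound 3 `O=C(Nc1cccc(C(F)(F)F)c1)c1cc(Cl)ccc1O` gives 5900 nM.

For the measured compounds named here, in an ADME assay on cells (Macrophage, Mus musculus) for cytotoxicity, read by resazurin assay, with a stated time of 3 days (a higher number here means a weaker inhibitor, a lower number a stronger inhibitor), compound 3 is the only one with a number; the values of compound 1 and compound 2 both sit at the limit of > 60000 nM in this assay, at which 2 of the 3 values shown sit. The step that the two limits leave unreadable from compound 1 to compound 2 is therefore unreadable. The change behind it is methoxy in place of hydrogen on an aromatic carbon.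

Compound 4 `COc1cc(NC(=O)c2cc(Cl)ccc2O)cc(C(F)(F)F)c1` is not yet measured. It differs from compound 3 by methoxy in place of hydrogen on an aromatic carbon, the same kind of change as from compound 1 to compound 2, though around a different place: there the methoxy enters ortho to a large group and para to a chloro group, here meta to a large group and meta to a trifluoromethyl group. How the core of compound 1 differs from that of compound 3 is not broken down here.

Going by the values given here, since the only measured instance of this change is unreadable, the expectation for compound 4 rests mainly on the value of compound 3, 5900 nM, with the new methoxy assumed to move the number only modestly. Compound 4 is expected to give about 8000 nM, within 2500 nM to 30000 nM. This estimate means a step of a 1.4-fold higher number from compound 3 to compound 4 (0.13 log units; within the scatter).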

Compound 4, half-maximal inhibitory concentration: 18000 nM
Compound 4: the middle estimate sits 2.3-fold (0.35 log units) below what was measured, and the stated range covers the measured number.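

In this assay, methoxy in place of hydrogen on an aromatic carbon, meta to a large group and meta to a trifluoromethyl group, brings a 3.1-fold higher number from compound 3 to compound 4 (0.48 log units; beyond the scatter), so on this core the change goes with a weaker inhibitor in the macrophage cells. For the compounds shown here, this is the only readable instance of the change, so it describes one place on one core and gives no rule for how methoxy behaves on other cores. The same change on the core of compound 1 cannot be read, and whether the step carries over to that core stays unknown, because compound 1 and compound 2 both stand at a limit rather than at a number: the limit of > 60000 nM in this assay, at which 2 of the 4 values shown sit.

The compounds shown leave open whether this step belongs to methoxy itself or would also appear with another group at the same place, such as an ethoxy, a longer chain, an amine or a carboxylic acid. They also leave open whether a methoxy at any other place on the core of compound 3 would give a step of similar size or direction.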